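Fluoro Added to Compound 2: An Expected Cytotoxicity

The source may hold more compounds than are shown below. What is called first, only, known or untested is meant among the compounds shown, and "the series" means these compounds.

Compound 1 `O=C(Nc1ccc(Oc2ccnc3[nH]ccc23)cc1)c1nn(-c2ccccc2)ccc1=O` gives 15000 nM in a functional assay on PC-3 cells (Homo sapiens) for cytotoxicity, read by MTT assay, with a stated time of 72 h; a lower number here means a stronger inhibitor, a higher number a weaker inhibitor. Compound 2 `Cn1ccc2c(Oc3ccc(NC(=O)c4nn(-c5ccccc5)ccc4=O)cc3)ccnc21` gives 58200 nM. Compound 3 `Cn1ccc2c(Oc3ccc(NC(=O)c4nn(-c5ccc(Br)cc5F)ccc4=O)cc3)ccnc21` gives 20500 nM.

Compound 2 holds the highest number of the three, so it is the weakest inhibitor in this set. Its neighbours are reached by two changes: a 3.9-fold higher number from compound 1 to compound 2 (0.59 log units; beyond the scatter), and a 2.8-fold lower number from compound 2 to compound 3 (0.45 log units; beyond the scatter). Both steps are modest and both lie beyond the scatter.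

Compound 4 `Cn1ccc2c(Oc3ccc(NC(=O)c4nn(-c5ccccc5)ccc4=O)cc3F)ccnc21` differs from compound 2 by fluoro in place of hydrogen on an aromatic carbon. Neither measured step touches this position: one concerns the aromatic nitrogen of the shared core, the other the group on the other aromatic nitrogen. So no measured step bears directly on the change, and the two that exist were modest in size. On this basis the step is expected to be small, probably within the scatter, with direction uncertain, and compound 4 is expected to sit near compound 2: a 1.5-fold lower number from compound 2 to compound 4 (0.16 log units; within the scatter). The estimated value for compound 4 in this assay is 40000 nM, with a range from 15000 nM to 120000 nM.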

Compound 4, half-maximal inhibitory concentration: > 60000 nM
Compound 4 was reported as a limit; the forecaster's own chance of this, stated with the estimate: 10%; middle value at least 1.5-fold (0.17 log units) from the limit.
By their numbers in this assay, from the lowest: compounds 1 and 3 (each within the scatter of the next); then compound 2. At a limit, above all of these: compound 4.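

Unlike the earlier steps, this one touches the carbon-only six-membered aromatic ring, at the carbon ortho to a large group and meta to a large group. In this assay fluoro at this place gives an at least 1.0-fold higher number from compound 2 to compound 4 (0.01 log units; that floor lies within the scatter) and so brings no lowering of the number, while the true size of the step cannot be read. Compound 4 is reported only as a limit of the assay, not as a number: the limit of > 60000 nM in this assay, at which 1 of the 4 values shown sits.

The compounds shown leave open how far past that limit compound 4 lies, and whether fluoro at this place would act the same on the core of compound 1, with hydrogen on the aromatic nitrogen. They also leave open what a methoxy group or an amine would do at this same carbon.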